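Swapping Sulfur for Selenium in a Weakly Active Series

A few compounds are considered here, and "the series" means these few. Any claim that something is new, unique, unknown or untested is made for them only; others in the source may bear on it.

Three compounds share a core built around a carbon with a double bond to nitrogen, whose other neighbours are amide-type nitrogens. In a functional assay on PC-3 cells (Homo sapiens) for cytotoxicity, read by MTT assay, with a stated time of 72 h (on this read-out higher numbers stand for weaker inhibition of growth and lower numbers for stronger inhibition of growth), compound 1 `CS/C(=N\C(=O)c1sccc1Cl)NC(=O)c1sccc1Cl` gives 24700 nM, compound 2 `CS/C(=N\C(=O)c1ccno1)NC(=O)c1ccno1` gives 99200 nM, and compound 3 `CS/C(=N\C(=O)c1ccco1)NC(=O)c1ccco1` gives 56200 nM. Compound 2 has the highest of the three numbers; its gap to compound 1 lies beyond the usual scatter, while its gap to compound 3 lies within it. Compound 4 `C[Se]/C(=N\C(=O)c1ccno1)NC(=O)c1ccno1` differs from compound 2 by a group of 2 heavy atoms (1 carbon, 1 selenium; no ring) in place of a group of 2 heavy atoms (1 carbon, 1 sulfur; no ring), on a carbon with a double bond to nitrogen. Going by the values given here, no measured pair shows this exchange, so nothing here tells its effect. In this assay the step is expected to be small, with no clear direction beyond the scatter. Compound 4 is estimated at 70000 nM, in the range 25000 nM to 200000 nM. That estimate means an expected step of a 1.4-fold lower number from compound 2 to compound 4 (0.15 log units; within the scatter).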

Compound 4, concentration for 50% growth inhibition: 90 nM
Beside the measured number, compound 4's estimate is 780-fold (2.89 log units) above it; measured number below the stated range.
By their numbers in this assay, from the lowest: compound 4; then compound 1; then compounds 3 and 2 (each within the scatter of the next).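

In this assay, going by these compounds alone, the single exchange of methylsulfanyl for the group of carbon and selenium, on a carbon with a double bond to nitrogen, brings a very large change (a 1100-fold lower number from compound 2 to compound 4 (3.04 log units; beyond the scatter)). Compound 1, compound 2 and compound 3 all carry methylsulfanyl, so they could show nothing about this position. No measurement shown here bears on why the step is so large.

Still open, on these data alone, is whether the same exchange works as strongly on compound 1 and compound 3. Also open, as far as these compounds go, is whether an ethyl group on the selenium, or an amine at this place, would keep the low number.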